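The source may report more compounds than this note shows. Statements on the series, on what has been measured and on what is new or still open speak of the compounds shown alone.

Measured in a functional assay on the whole organism (strain Kunming) with Mus musculus as the target, with a stated time of 0.5 h, at a dose of 100 mg/kg by the intraperitoneal route; a higher number here means a weaker effect of the compound at the dose given, a lower number a stronger effect:

compound 1, `COc1cc(OC)c(OC)cc1/C=C/COC(=O)/C=C/c1cc(OC)c(OC)c(OC)c1OC`: 100%
compound 2, `COc1cc(OC)c(OC)cc1/C=C/COC(=O)/C=C/c1ccccc1C(F)(F)F`: 100%
compound 3, `COc1cc(OC)c(OC)cc1/C=C/COC(=O)/C=C/c1ccc(OC)c(OC)c1OC`: 100%

All three measured compounds share the same ester-linked core and differ only in the aryl group on the cinnamate side. Among the measured compounds shown here, the one step measured in one place, no change at the digits printed from compound 1 to compound 3 (within the scatter), shows that removing a methoxy from that aryl ring does not move the read-out. Compound 2, which carries a 2-(trifluoromethyl)phenyl in this position, stands level with compound 1 and compound 3 at the digits shown; no step between compound 2 and either of them is beyond the scatter, so nothing separates the three on these numbers.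

Compound 4, `COc1ccc(/C=C/C(=O)OC/C=C/c2cc(OC)c(OC)cc2OC)cc1`, is yet to be tested in this assay. It differs from compound 2 by 4-methoxyphenyl in place of 2-(trifluoromethyl)phenyl on a double-bonded chain carbon bound to a double-bonded chain carbon. For the measured compounds named here, no measured step covers an exchange of this kind; the only step available, from compound 1 to compound 3, concerns a methoxy-for-hydrogen swap on an already methoxylated ring and was flat. With every measured aryl variant, including compound 2, at the same level, no change beyond the scatter is expected for compound 4, so the estimated step of no change at the digits printed from compound 2 to compound 4 (within the scatter) is essentially nil. Compound 4 is therefore expected to give 100%, within 85% to 100%.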

Compound 4, a percentage reported as activity, at one dose (the size of the read-out at that dose, not a potency): 100%
Beside the measured number, compound 4's estimate shows no gap at the digits printed, and the stated range covers the measured number.
By their numbers in this assay, from the lowest: compounds 1, 2, 3 and 4 (each within the scatter of the next).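

In this assay, 4-methoxyphenyl in place of 2-(trifluoromethyl)phenyl on a double-bonded chain carbon bound to a double-bonded chain carbon gives no change at the digits printed from compound 2 to compound 4 (within the scatter). The earlier step covered only hydrogen in place of methoxy on an already methoxylated ring, whereas this one replaces the whole aryl group, exchanging a fluorine-bearing substituent for an oxygen-bearing one, and the read-out still does not move at the digits printed. This position therefore tolerates a wider exchange than the earlier compounds showed, at least for these two phenyl groups, although no measurement here offers an explanation for the flat result.

With all four compounds level in this assay, the series does not yet show any group at this position that lowers the read-out, so the position has no demonstrated influence on it in either direction. Going by these compounds, it remains open whether an amine or a carboxylic acid on this aryl ring, or a longer chain in place of the ring, would separate from compound 4.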